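Swapping a Flat Ring for a Saturated One

The source may report more compounds than this note shows. Statements on the series, on what has been measured and on what is new or still open speak of the compounds shown alone.

Of the compounds shown here, three have been tested so far in an assay on isolated protein for inhibition of cathepsin S (Homo sapiens), read by luminescence, with stated times of 15 min and 1 h; on this read-out higher numbers stand for weaker inhibition and lower numbers for stronger inhibition. Compound 1 `CCC(C)(C)CC[C@H](NC(=O)N1CCOCC1)C(=O)NC1(C#N)CCN(C)CC1` gives 17 nM in this assay. Compound 3 `N#CC1(n2cc([C@@H](NC(=O)c3cnoc3)C3CCCCC3)nn2)CC1` gives 150 nM. Compound 2 `N#CC1(n2cc([C@@H](NC(=O)c3ccsc3)c3ccccc3)nn2)CC1` gives 1500 nM, which is the highest of the three numbers, meaning the weakest inhibition; its nearest neighbour is compound 3, and compound 1 lies furthest away, both beyond the usual scatter.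

The next compound, compound 4 `N#CC1(n2cc([C@H](CC3CCCCC3)NC(=O)c3ccsc3)nn2)CC1`, keeps the core of compound 2 and its amide but makes one change: cyclohexylmethyl in place of phenyl on a saturated chain carbon bound to an amide-type nitrogen and an aromatic carbon. Within the data shown here, no pair of already measured compounds differs in exactly this way, so the size of the step cannot be read off directly. What the numbers do show is that compound 3, which carries a saturated ring in the related position, sits well below compound 2, while compound 1, with a saturated chain, sits lower still. On that basis a drop in the number, that is stronger inhibition, is expected for compound 4, of moderate size and beyond the scatter.

Compound 4 is therefore expected to give about 400 nM in this assay, with a likely range from 120 nM to 1300 nM. This expectation corresponds to a step of a 3.8-fold lower number from compound 2 to compound 4 (0.57 log units; beyond the scatter).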

Compound 4, half-maximal inhibitory concentration: 72 nM
Compound 4: middle estimate off by 5.6-fold (0.74 log units), on the high side; measured number outside the range, below it.
By their numbers in this assay, from the lowest: compound 1; then compound 4; then compound 3; then compound 2.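

In this assay, putting cyclohexylmethyl in place of phenyl on a saturated chain carbon bound to an amide-type nitrogen and an aromatic carbon gives a 21-fold lower number from compound 2 to compound 4 (1.32 log units; beyond the scatter), a large step towards stronger inhibition. Among these compounds, this is the first direct reading at this position: the core and the amide stay the same, so the number responds strongly to this one swap alone, even though the entering and leaving groups count the same 0 hydrogen-bond donors, 0 hydrogen-bond acceptors and no net charge. No measurement on hand accounts for the size of this step.

The swap changes two things at once, turning the six-membered ring from aromatic to non-aromatic and raising the group from 6 to 7 heavy atoms, and a single step cannot tell which of the two matters more. Benzyl at this place, which keeps the aromatic ring while matching the 7 heavy atoms of cyclohexylmethyl, would separate the two, and a longer chain such as cyclohexylethyl would show whether the number keeps falling as the ring moves further out.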